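The source may hold more compounds than are shown below. What is called first, only, known or untested is meant among the compounds shown, and "the series" means these compounds.

Of the compounds shown here, three built on one shared core have been measured in a functional assay on HT-1080 cells (Homo sapiens) for inhibition, read by MTT assay, with a stated time of 48 h; a higher number here means a weaker inhibitor, a lower number a stronger inhibitor. Compound 1 `COc1cc(-c2nc3cc(/C=C4\SC(=O)NC4=O)ccc3[nH]2)cc(OC)c1OC` carries a hydrogen on the amide-type nitrogen in its ring; in this assay compound 1 gives 3120 nM. Compound 2 `COc1cc(-c2nc3cc(/C=C4\SC(=O)N(CC(=O)N5CCOCC5)C4=O)ccc3[nH]2)cc(OC)c1OC` has a ((morpholin-4-yl)carbonyl)methyl group on that nitrogen instead, and in this assay compound 2 gives 1680 nM. The step of a 1.9-fold lower number from compound 1 to compound 2 (0.27 log units; within the scatter) thus stays inside the scatter. Compound 3 `COc1cc(OC)c(-c2nc3cc(/C=C4\SC(=O)N(CC(=O)N5CCOCC5)C4=O)ccc3[nH]2)cc1OC` differs from compound 2 in that a 2,4,5-trimethoxyphenyl group replaces the 3,4,5-trimethoxyphenyl; in this assay compound 3 gives 1120 nM, and the step of a 1.5-fold lower number from compound 2 to compound 3 (0.18 log units; within the scatter) also remains within the scatter. Among the three numbers, compound 2 stands second highest, with compound 3 nearest and compound 1 furthest, both within the scatter of it.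

Compound 4 `COc1cc(-c2nc3cc(/C=C4\SC(=O)N(CC(=O)N5CCCCC5)C4=O)ccc3[nH]2)cc(OC)c1OC` is compound 2 with a single change: piperidin-1-yl in place of morpholin-4-yl on a carbonyl carbon. Within the data shown here, no measured step varies this part of the side chain. The closest evidence is the step of a 1.9-fold lower number from compound 1 to compound 2 (0.27 log units; within the scatter), which introduced the whole side chain without moving the number beyond the scatter, so exchanging the ring at its end is expected to give no step beyond the scatter in this assay. The expected step is a 1.0-fold higher number from compound 2 to compound 4 (0.01 log units; within the scatter). Compound 4 is therefore estimated at 1700 nM, with a likely range from 800 nM to 3600 nM.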

Compound 4, half-maximal inhibitory concentration: 3650 nM
Compound 4: middle estimate off by 2.1-fold (0.33 log units), on the low side; the measured number lies above the stated range.
By their numbers in this assay, from the lowest: compounds 3, 2, 1 and 4 (each within the scatter of the next, the first and the last beyond it).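

In this assay, among these compounds, the step of a 2.2-fold higher number from compound 2 to compound 4 (0.34 log units; beyond the scatter) is modest, but it is the first single change to go beyond the scatter, and it shows that the ring at the far end of the side chain can shift the number even though both rings have the same count of heavy atoms: piperidin-1-yl has 5 carbon and 1 nitrogen, whereas morpholin-4-yl has 4 carbon, 1 nitrogen and 1 oxygen. The step of a 1.2-fold higher number from compound 1 to compound 4 (0.07 log units; within the scatter) stays within the scatter, as does the earlier step from hydrogen to the morpholine-bearing side chain, so neither complete side chain can be told apart from plain hydrogen on the amide-type nitrogen, although the two side chains can be told apart from each other. Nothing available explains the difference between these two rings.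

On these data alone, it remains open whether the shift follows the ring oxygen itself, which a piperazin-1-yl or a pyrrolidin-1-yl group on the same carbonyl carbon would help to show. An open-chain diethylamino group there would also show whether a ring is needed at all.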